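Cyclopentyl gives way to 3-hydroxypropyl

This account rests on a few compounds, and the source may have more. Where it says the series, first, only, none or still open, it means among the compounds named here.

In a functional assay on DU-145 cells (Homo sapiens) for antiproliferative activity, read by sulforhodamine B assay, with a stated time of 48 h (a higher number here means a weaker inhibitor of growth, a lower number a stronger inhibitor of growth), compound 1 (`COc1ccc(Nc2nc(NCCCO)c3ccccc3n2)cc1`) gives 18300 nM and compound 2 (`COc1ccc(N(C)c2nc(NC3CCCC3)c3ccccc3n2)cc1`) gives 10200 nM, two numbers within the usual scatter of each other. Compound 3 (`COc1ccc(N(C)c2nc(NCCCO)c3ccccc3n2)cc1`) differs from compound 2 in one place: 3-hydroxypropyl in place of cyclopentyl on a nitrogen on an aromatic ring. Within the data shown here, no measured pair shows this exact swap. Compound 1 also carries 3-hydroxypropyl and gives 18300 nM, which points to a small move towards weaker inhibition at most. The expected step is a 1.7-fold higher number from compound 2 to compound 3 (0.22 log units; within the scatter), no larger than the scatter. Compound 3 is estimated at 17000 nM, with an expected range of 8000 nM to 38000 nM.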

Compound 3, concentration for 50% growth inhibition: 30200 nM
Compound 3: middle estimate off by 1.8-fold (0.25 log units), on the low side; measured number inside the range.
By their numbers in this assay, from the lowest: compounds 2, 1 and 3 (each within the scatter of the next, the first and the last beyond it).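

In this assay, 3-hydroxypropyl in place of cyclopentyl on a nitrogen on an aromatic ring gives a 3.0-fold higher number from compound 2 to compound 3 (0.47 log units; beyond the scatter), the first clear sign that this position responds to the group it carries, with cyclopentyl the better of these two. Methyl in place of hydrogen on a nitrogen on an aromatic ring gives a 1.7-fold higher number from compound 1 to compound 3 (0.22 log units; within the scatter), so that change cannot be told from the scatter. Nothing at hand explains the gap between cyclopentyl and 3-hydroxypropyl.

Still open, as far as these compounds go, is how a cyclohexyl ring or a 3-aminopropyl chain would read at this position. From the compounds shown here alone, it is also open whether cyclopentyl keeps its edge with hydrogen in place of the methyl.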